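A Benzyl Chain on the Shared Core of Compound 3

The compounds below may be only part of what the source reports. "The series", "measured", "known", "first", "only" and "open" are said of these compounds alone.

Compound 3 `CCCCNc1nc(NCCCC)c2ccccc2n1` carries a butyl chain on each of the two nitrogens attached to the shared core. In a physicochemical assay for solubility, at pH 2 (a higher number here means a more soluble compound, a lower number a less soluble compound), compound 3 gives >= 30000 nM, which is a limit of the assay. The two companions stand at the same point. Compound 1 `CC(C)Nc1nc(NCc2ccco2)c2ccccc2n1` gives in this assay >= 30000 nM, also a limit. Compound 2 `CCOC(=O)CNc1nc(NC(C)C)nc2ccccc12` gives in this assay >= 30000 nM, again a limit. Within the data shown here, the one step between measured compounds, a step that the two limits leave unreadable from compound 1 to compound 2, therefore cannot be read in size. What the three share is the limit of >= 30000 nM in this assay, at which 3 of the 3 values shown sit.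

Compound 4 `CCCCNc1nc(NCc2ccccc2)c2ccccc2n1` differs from compound 3 by phenyl in place of propyl on a saturated chain carbon bound to a nitrogen on an aromatic ring. Among the measured compounds shown here, no measured step bears directly on this exchange; the step from compound 1 to compound 2 concerns a different pair of groups and is itself unreadable. With every measured value resting at the same limit (the limit of >= 30000 nM in this assay, at which 3 of the 3 values shown sit), the expected outcome for compound 4 is no change beyond the scatter, expressed as a number no higher from compound 3 to compound 4 (the limit leaves the size open). Compound 4 is thus expected to give in this assay about 30000 nM, with a range from 10000 nM to 100000 nM, and most likely to be returned once more as a limit.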

Compound 4, solubility: >= 30000 nM
Compound 4: a limit, no number; the forecaster's own chance of this, stated with the estimate: 70%; the middle value lies on the limit itself.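

Compound 4 gives >= 30000 nM in this assay, which is a limit of the assay, so the step from compound 3 to compound 4 cannot be read in size. The compounds shown leave open how far each lies past that limit, and so whether phenyl in place of propyl alters the read-out at all: the limit of >= 30000 nM in this assay, at which 4 of the 4 values shown sit.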